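A Cytotoxicity Series: Cyclopentyl Gives Way to Pyridin-4-yl

The source may report more compounds than this note shows. Statements on the series, on what has been measured and on what is new or still open speak of the compounds shown alone.

Measured in a functional assay on HeLa cells (Homo sapiens) for cytotoxicity, read by WST assay, with a stated time of 48 h; a lower number here means a stronger inhibitor, a higher number a weaker inhibitor:
compound 1 `COc1ccc(CCC[C@H]2C[C@@H]([C@@H](O)c3ccc(OC)c(OC)c3)CO[C@@H]2c2ccc(OC)c(OC)c2)cc1OC`: 37700 nM
compound 2 `COc1cccc(/C=C/C[C@@H]2C[C@@H]([C@@H](O)c3ccc(OC)c(OC)c3)CO[C@H]2c2ccc(OC)c(OC)c2)c1`: 16400 nM
compound 3 `O[C@@H](c1ccccc1)[C@H]1CO[C@H](c2ccccc2)[C@@H](C/C=C/C2CCCC2)C1`: 9330 nM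

Compound 3 gives the lowest of the three numbers in this assay. Its gap to compound 2 lies within the scatter, so no order between those two can be claimed; its gap to compound 1 lies beyond the scatter.

Compound 4 `O[C@@H](c1ccccc1)[C@H]1CO[C@H](c2ccccc2)[C@@H](C/C=C/c2ccncc2)C1` has not been measured. It differs from compound 3 in one place: pyridin-4-yl in place of cyclopentyl on a double-bonded chain carbon bound to a double-bonded chain carbon. No step between measured compounds involves this change, so its size and direction are unknown from the data shown here. The expected step of a 1.2-fold lower number from compound 3 to compound 4 (0.07 log units; within the scatter) in this assay is therefore small and of uncertain direction. For compound 4 the estimate in this assay is 8000 nM, expected to fall between 2500 nM and 25000 nM.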

Compound 4, half-maximal inhibitory concentration: > 100000 nM
Compound 4: no number, only a limit; the forecaster's own chance of this, stated with the estimate: 10%; middle value at least 12-fold (1.09 log units) away from the limit.
By their numbers in this assay, from the lowest: compounds 3 and 2 (each within the scatter of the next); then compound 1. At a limit, above all of these: compound 4.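

In this assay compound 4 gives only a limit, > 100000 nM. Pyridin-4-yl in place of cyclopentyl on a double-bonded chain carbon bound to a double-bonded chain carbon is an at least 10-fold higher number from compound 3 to compound 4 (1.03 log units; beyond the scatter), the first single change shown at this position. Within the data shown here, the number in this assay therefore depends strongly on the ring at this chain end, which the earlier compounds, differing from one another in several places, could not show. The compounds shown leave open whether this step follows from the ring nitrogen or from the aromatic ring as such. A phenyl or a cyclohexyl at this place would separate the two.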